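Ring-substituted succinimide amides in the electroshock model

The source may report more compounds than this note shows. Statements on the series, on what has been measured and on what is new or still open speak of the compounds shown alone.

Compound 1 `CCC(C(=O)NCc1ccccc1)N1C(=O)CCC1=O` is the unsubstituted parent of the series. For the measured compounds named here, in a functional assay on the whole organism (strain Albino Swiss CD1) with Mus musculus as the target, in the maximal electroshock model (on this read-out higher numbers stand for an effect only at larger amounts of compound and lower numbers for an effect already at smaller amounts), compound 1 gives 73.3 mg/kg, the lowest of the two numbers so far; its nearest neighbour is compound 2 `CCC(C(=O)NCc1cccc(Cl)c1)N1C(=O)CCC1=O`, which gives 96.6 mg/kg in this assay. Compound 3 `CCC(C(=O)NCc1ccc(F)cc1)N1C(=O)CCC1=O` has no result in this assay, with "not determined" (no result reported). Compound 4 `CCC(C(=O)NCc1ccccc1C(F)(F)F)N1C(=O)CCC1=O` carries trifluoromethyl in place of hydrogen on an aromatic carbon, on an aromatic carbon of a six-membered aromatic ring of carbon only, ortho to a large group. Going by the values given here, the only step that bears on a ring substituent is a 1.3-fold higher number from compound 1 to compound 2 (0.12 log units; within the scatter), which stayed within the scatter. No step beyond the scatter is therefore expected in this assay, and for compound 4 the estimate is 90 mg/kg (range 45 mg/kg to 180 mg/kg), a step of a 1.2-fold higher number from compound 1 to compound 4 (0.09 log units; within the scatter) expected from compound 1.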

Compound 4, dose for half-maximal effect: > 150 mg/kg
Compound 4: only a limit was reported; the forecaster's own chance of this, stated with the estimate: 10%; at least 1.6-fold (0.22 log units) between middle value and limit.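

Trifluoromethyl on an aromatic carbon, ortho to a large group, gives an at least 2.0-fold higher number from compound 1 to compound 4 (0.31 log units; beyond the scatter) in this assay, the first ring change shown to lie beyond the scatter, whereas chloro gives a 1.3-fold higher number from compound 1 to compound 2 (0.12 log units; within the scatter). Compound 4 has a limit and not a number, so the full size of this step remains unknown: the limit of > 150 mg/kg in this assay, at which 1 of the 4 values shown sits.

Open, from the compounds shown here alone, is whether a methyl or a methoxy group at this place gives a step of the same kind. Also open, going by these compounds, is whether the step depends on the group or on its place.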